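This account rests on a few compounds, and the source may have more. Where it says the series, first, only, none or still open, it means among the compounds named here.

Working notes on the series. In an assay on HeLa cells for inhibition of sphingosine-1-phosphate transporter SPNS2 (Mus musculus), read by LC-MS, tested at 2 uM (on this read-out higher numbers stand for more inhibition at the one concentration tested (going by the name of the read-out) and lower numbers for less inhibition), compound 1 `CCCCCCCCCCc1ccc(-c2noc(CCCNC)n2)cc1` gives 45%. Compound 2 `CCCCCCCCCCc1ccc(-c2noc(CCCN(C)C)n2)cc1` gives 8%, and compound 3 `CCCCCCCCCCc1ccc(-c2noc([C@@H]3CCNC3)n2)cc1` gives 62%. On these three numbers compound 2 stands lowest, with compound 1 nearest above it and compound 3 furthest. Both steps that touch it lie beyond the scatter: a number 37 percentage points lower from compound 1 to compound 2 (beyond the scatter), and a number 54 percentage points higher from compound 2 to compound 3 (beyond the scatter). Between the other two, a number 17 percentage points higher from compound 1 to compound 3 (beyond the scatter).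

Compound 4 `CCCCCCCCCCc1ccc(-c2noc(CN3CCNCC3)n2)cc1` is not yet measured. Against compound 2 the change is piperazin-1-yl in place of 2-(dimethylamino)ethyl on a saturated chain carbon bound to an aromatic carbon. The group that leaves carries no hydrogen-bond donor; the group that enters carries one, set in a six-membered non-aromatic ring with two hetero atoms.

Going by the values given here, two measured steps bear on this. The step with methyl in place of hydrogen on an amine nitrogen cost a large amount, and the step to pyrrolidin-3-yl in place of 3-(dimethylamino)propyl, which likewise brings in a ring with a hydrogen-bond donor, gained a large amount. A large rise in this assay is therefore expected for compound 4, though the ring and the point of attachment differ from compound 3, so the size is uncertain. The step this estimate means is expected to read a number 42 percentage points higher from compound 2 to compound 4 (beyond the scatter). Compound 4 is expected to give about 50%, within a range from 25% to 70%.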

Compound 4, a percentage reported as inhibition, at one concentration (the size of the read-out at that concentration, not a potency): 19%
Compound 4: middle estimate off by 31 percentage points, on the high side, and the stated range ends above it.
By their numbers in this assay, from the lowest: compound 2; then compound 4; then compound 1; then compound 3.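

In this assay, a ring that carries a hydrogen-bond donor does not by itself bring the gain seen with compound 3: piperazin-1-yl in place of 2-(dimethylamino)ethyl gives a number 11 percentage points higher from compound 2 to compound 4 (beyond the scatter) and no more than a modest rise, while (piperazin-1-yl)methyl in place of pyrrolidin-3-yl gives a number 43 percentage points lower from compound 3 to compound 4 (beyond the scatter) and a large loss. The open chain of compound 1 also keeps an edge over this ring, with a number 26 percentage points lower from compound 1 to compound 4 (beyond the scatter) as a modest step, so at this position the outcome depends on which donor-bearing group is present and how it is attached, not merely on whether a donor is there. No measurement at hand accounts for the gap between the pyrrolidin-3-yl and (piperazin-1-yl)methyl groups.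

Ring size, the second ring nitrogen and the point of attachment all change together from compound 3 to compound 4, and these compounds do not separate them. A piperidin-4-yl or a piperazin-2-yl on the aromatic carbon, or a (pyrrolidin-3-yl)methyl on that same carbon, would begin to pull these apart.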